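The source may report more compounds than this note shows. Statements on the series, on what has been measured and on what is new or still open speak of the compounds shown alone.

Measured in an in vitro ADME assay on microsomes from liver (Rattus norvegicus) for metabolic stability; on this read-out higher numbers stand for fast clearance and lower numbers for slow clearance (both values are limits):
Compound 1 `Cc1ccc(Cn2c(=O)[nH]c3c(N)nc(C(F)(F)F)cc32)nn1` gives < 11 mL.min-1.g-1
Compound 2 `Cc1nc(Cn2c(=O)[nH]c3c(N)nc(C(F)(F)F)cc32)cs1` gives < 10 mL.min-1.g-1

Compound 2 has only a limit and no number. Compound 3 `COc1ccc(Cn2c(=O)[nH]c3c(N)nc(C(F)(F)F)cc32)cn1` carries 6-methoxypyridin-3-yl in place of 2-methyl-1,3-thiazol-4-yl on a saturated chain carbon bound to an aromatic nitrogen and has not been measured. Among the compounds with values here, the one measured step that the two limits leave unreadable from compound 1 to compound 2 has no readable size, so it offers no direction or size to carry over. No step beyond the scatter is therefore expected in this assay and the expected move an at least 1.2-fold higher number from compound 2 to compound 3 (0.07 log units; that floor lies within the scatter) stays small. Compound 3 is estimated at 12 mL.min-1.g-1 (expected range 6 mL.min-1.g-1 to 30 mL.min-1.g-1).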

Compound 3, intrinsic clearance in microsomes: < 9 mL.min-1.g-1
Compound 3 was reported as a limit; the forecaster's own chance of this, stated with the estimate: 50%; middle value at least 1.3-fold (0.12 log units) from the limit.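

Within the data shown here, compound 1, compound 2 and compound 3 all stand as limits in this assay, so no step among them can be read. The compounds shown leave open whether exchanging the group on the saturated chain carbon bound to an aromatic nitrogen changes clearance at all.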